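Swapping a naphthalene arm for a chlorinated benzyl group

The source may hold more compounds than are shown below. What is called first, only, known or untested is meant among the compounds shown, and "the series" means these compounds.

Three compounds with the same sulfonyl-guanidine core were tested in a functional assay on MCF7 cells (Homo sapiens) for cytotoxicity, read by MTT assay, with a stated time of 72 h; on this read-out higher numbers stand for weaker inhibition and lower numbers for stronger inhibition. Compound 2 `Cc1cc(-c2ccccc2)n(/C(N)=N/S(=O)(=O)c2cc(C)c(Cl)cc2SCc2ccc(C(F)(F)F)cc2)n1` gives 16000 nM, compound 1 `Cc1cc(S(=O)(=O)/N=C(\N)n2nccc2-c2ccccc2)c(SCc2ccccc2Cl)cc1Cl` gives 24000 nM, and compound 3 `Cc1cc(-c2ccccc2)n(/C(N)=N/S(=O)(=O)c2cc(C)c(Cl)cc2SCc2cccc3ccccc23)n1` gives 170000 nM, the highest of the three numbers. For the measured compounds named here, the one step measured on this core, an 11-fold higher number from compound 2 to compound 3 (1.03 log units; beyond the scatter), shows that putting naphthalen-1-yl onto the saturated chain carbon bound to a sulfur raised the number sharply. Compound 4 `Cc1cc(-c2ccccc2)n(/C(N)=N/S(=O)(=O)c2cc(C)c(Cl)cc2SCc2ccccc2Cl)n1` reverses that kind of move: 2-chlorophenyl in place of naphthalen-1-yl on a saturated chain carbon bound to a sulfur. Compound 1, which already carries 2-chlorophenyl at that spot on a related core, sits far below compound 3. A large step downward is therefore expected, a 6.8-fold lower number from compound 3 to compound 4 (0.83 log units; beyond the scatter), so compound 4 is estimated at 25000 nM, within 10000 nM to 65000 nM.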

Compound 4, half-maximal inhibitory concentration: 135000 nM
Beside the measured number, compound 4's estimate is 5.4-fold (0.73 log units) below it; the whole stated range lies below it.
By their numbers in this assay, from the lowest: compounds 2 and 1 (each within the scatter of the next); then compounds 4 and 3 (each within the scatter of the next).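

On the shared core, the change gives a 1.3-fold lower number from compound 3 to compound 4 (0.10 log units; within the scatter) so 2-chlorophenyl and naphthalen-1-yl cannot be told apart on this saturated chain carbon bound to a sulfur. 4-(Trifluoromethyl)phenyl at that spot stands apart, as 2-chlorophenyl in its place gives an 8.4-fold higher number from compound 2 to compound 4 (0.93 log units; beyond the scatter) and so the smaller ring alone does not set the lower number. The 2-chlorophenyl result also depends on the rest of the molecule, as methyl in place of hydrogen on an aromatic carbon gives a 5.6-fold higher number from compound 1 to compound 4 (0.75 log units; beyond the scatter) with the arm unchanged. On these data alone, how a plain phenyl group or a longer chain would compare on that carbon remains open. No measured evidence accounts for these steps.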